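The source may report more compounds than this note shows. Statements on the series, on what has been measured and on what is new or still open speak of the compounds shown alone.

In a functional assay on HepG2 cells (Homo sapiens) for antiproliferative activity, read by MTT assay, with a stated time of 48 h (on this read-out lower numbers stand for stronger inhibition and higher numbers for weaker inhibition), compound 1 (`COc1ccc(C2OC(c3ccc4ccccc4c3)=NN2C(C)=O)cc1`) gives 3.6 ug/mL and compound 2 (`CC(=O)N1N=C(c2ccc3ccccc3c2)OC1c1ccc(F)cc1`) gives 1.82 ug/mL on the same read-out. Among the measured compounds shown here, these are the only two numbers so far. They lie within the scatter of each other, so compound 2 cannot be ranked against compound 1.

The next structure is compound 3 (`CC(=O)N1N=C(c2ccc3ccccc3c2)OC1c1cccnc1`), in which pyridin-3-yl stands in place of 4-fluorophenyl on a saturated ring carbon (pyridin-3-yl in place of 4-fluorophenyl on a saturated ring carbon). For the measured compounds named here, only one measured step bears on this change: a 2.0-fold lower number from compound 1 to compound 2 (0.30 log units; within the scatter) with fluoro in place of methoxy on an aromatic carbon. That step stays within the scatter, but it alters only a substituent on the aromatic ring. Going by the values given here, no measured pair changes the ring itself, so the evidence is thin. No step beyond the scatter is therefore expected in this assay, with only a slight expected lean towards a higher number. The estimated move is a 1.4-fold higher number from compound 2 to compound 3 (0.14 log units; within the scatter) and carries a wide margin. For compound 3 the expected value is 2.5 ug/mL (estimated range 1 ug/mL to 6.5 ug/mL).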

Compound 3, half-maximal inhibitory concentration: 2.86 ug/mL
Compound 3: middle estimate off by 1.1-fold (0.06 log units), on the low side; low and high end bracket the measured number.
By their numbers in this assay, from the lowest: compounds 2, 3 and 1 (each within the scatter of the next).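

Among the compounds shown here, this is the first change to the aromatic ring itself at the saturated ring carbon, not just to a substituent on that ring: pyridin-3-yl brings a ring nitrogen and a hydrogen-bond acceptor in place of the carbon-only ring of 4-fluorophenyl. In this assay, for the compounds shown here, this gives a step within the scatter (a 1.6-fold higher number from compound 2 to compound 3 (0.20 log units; within the scatter)), and the comparison with the 4-methoxyphenyl compound also stays within the scatter (a 1.3-fold lower number from compound 1 to compound 3 (0.10 log units; within the scatter)), so the position accepts a ring with a hetero atom with no step that can be read, and compounds 1, 2 and 3 remain unranked. Nothing on hand accounts for this result or shows what the ring nitrogen does here.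

Still open, going by these compounds, is whether any group at this carbon gives a step beyond the scatter, for example pyridin-2-yl or pyridin-4-yl, a non-aromatic cyclohexyl ring, a longer alkyl chain, or a phenyl ring carrying an amine or a carboxylic acid. The acetyl group on the ring nitrogen also stays unchanged across these compounds, so a propanoyl group there remains an open comparison.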